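Adding a second methoxy to compound 3

The compounds below may be only part of what the source reports. "The series", "measured", "known", "first", "only" and "open" are said of these compounds alone.

Of the compounds shown here, three sharing one core have been tested in a functional assay on HeLa cells (Homo sapiens) for inhibition, read by MTT assay, with a stated time of 48 h; a higher number here means a weaker inhibitor of growth, a lower number a stronger inhibitor of growth. Compound 1 `Cn1cc(C2CC(c3ccccc3)=NN2C(=O)c2cccnc2)c2cc(Br)ccc21` gives 1730 nM, compound 2 `Cn1cc(C2CC(c3ccc(Cl)cc3)=NN2C(=O)c2cccnc2)c2cc(Br)ccc21` gives 5200 nM, and compound 3 `COc1ccc(C2=NN(C(=O)c3cccnc3)C(c3cn(C)c4ccc(Br)cc34)C2)cc1` gives 890 nM. Two steps show where the last of these stands. The step of a 5.8-fold lower number from compound 2 to compound 3 (0.77 log units; beyond the scatter) is a real gap, whereas the step of a 1.9-fold lower number from compound 1 to compound 3 (0.29 log units; within the scatter) cannot be told apart from repeat noise. Compound 3 therefore sits level with compound 1 and clear of compound 2.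

The next structure is compound 4 `COc1ccc(C2=NN(C(=O)c3cccnc3)C(c3cn(C)c4ccc(Br)cc34)C2)cc1OC`. The change is methoxy in place of hydrogen on an aromatic carbon, ortho to a methoxy group, turning 4-methoxyphenyl to 3,4-dimethoxyphenyl.

Within the data shown here, the closest precedent is the first methoxy, a 1.9-fold lower number from compound 1 to compound 3 (0.29 log units; within the scatter), which is the same kind of swap and stayed within the scatter. The chloro swap, a 3.0-fold higher number from compound 1 to compound 2 (0.48 log units; beyond the scatter), is a warning that a single group on this ring can move the number modestly. Among the measured compounds shown here, no tested compound carries two methoxy groups, so this precedent is only a loose guide.

The expected change is a 1.1-fold lower number from compound 3 to compound 4 (0.05 log units; within the scatter), which would be no step beyond the scatter. Compound 4 is estimated at 800 nM, with an expected range from 300 nM to 2400 nM.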

Compound 4, concentration for 50% growth inhibition: 2090 nM
Compound 4: the middle estimate sits 2.6-fold (0.42 log units) below what was measured; measured number inside the range.
By their numbers in this assay, from the lowest: compounds 3, 1 and 4 (each within the scatter of the next, the first and the last beyond it); then compound 2.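

In this assay, this position shows that a methoxy on the ring cannot be treated as a repeatable change: the first gave a 1.9-fold lower number from compound 1 to compound 3 (0.29 log units; within the scatter) and the second, ortho to a methoxy group, gave a 2.3-fold higher number from compound 3 to compound 4 (0.37 log units; beyond the scatter) with the number moving the opposite way. Read against the other rings, 3,4-dimethoxyphenyl stands level with plain phenyl in a 1.2-fold higher number from compound 1 to compound 4 (0.08 log units; within the scatter) and still clear of 4-chlorophenyl in a 2.5-fold lower number from compound 2 to compound 4 (0.40 log units; beyond the scatter) even though it has lost the lowest number of the set to compound 3. The data shown contain no measurement that could explain why adding this methoxy raises the number.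

Going by these compounds, what stays open is whether the rise comes from a methoxy on this carbon by itself or only from having two methoxy groups together on the ring. It is also unknown how a hydroxy group, an amine or an ethoxy group on this same carbon would read, so one result cannot yet define what this position tolerates.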